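Trifluoromethyl removal on two cores in the K562 series

This account rests on a few compounds, and the source may have more. Where it says the series, first, only, none or still open, it means among the compounds named here.

Measured compounds:
compound 1 `Cc1ccc(-n2cc(-c3ccc(CN4CCN(C)CC4)cc3)nn2)cc1Nc1nccc(-c2cccnc2)n1` gives 790 nM
compound 2 `Cc1ccc(-n2cc(-c3ccc(CN4CCN(C)CC4)c(C(F)(F)F)c3)nn2)cc1Nc1nccc(-c2cccnc2)n1` gives 40 nM
compound 3 `Cc1ccc(-c2nnc(-c3ccc(CN4CCN(CCN=C=S)CC4)c(C(F)(F)F)c3)o2)cc1Nc1nccc(-c2cccnc2)n1` gives 500 nM

All three values come from a functional assay on K562 cells (Homo sapiens) for inhibition, read by MTT assay, with a stated time of 72 h; on this read-out lower numbers stand for stronger inhibition and higher numbers for weaker inhibition. Within the first core, a 20-fold higher number from compound 2 to compound 1 (1.30 log units; beyond the scatter) for the change (hydrogen in place of trifluoromethyl on an aromatic carbon). Compound 3 carries a different core; the difference between the two cores is not broken down here, and the values of compound 2 and compound 3 are simply far apart in this assay.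

Compound 4 `Cc1ccc(-c2nnc(-c3ccc(CN4CCN(CCN=C=S)CC4)cc3)o2)cc1Nc1nccc(-c2cccnc2)n1` differs from compound 3 by hydrogen in place of trifluoromethyl on an aromatic carbon. The surroundings of the place are not the same word for word: in the step from compound 2 to compound 1 the carbon is ortho to a (4-methylpiperazin-1-yl)methyl group, whereas here it is ortho to a large group; this is the same kind of change, not the same change.

With only one prior occurrence, on another core, the step is expected to be large in the same direction: a 10-fold higher number from compound 3 to compound 4 (1.00 log units; beyond the scatter) is expected, because a 20-fold higher number from compound 2 to compound 1 (1.30 log units; beyond the scatter). Compound 4 is therefore estimated at 5000 nM in this assay, with a range of 1500 nM to 20000 nM.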

Compound 4, half-maximal inhibitory concentration: 920 nM
Compound 4: the middle estimate sits 5.4-fold (0.74 log units) above what was measured, outside the stated range (below it).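

In this assay, the replacement of trifluoromethyl by hydrogen on the second core gives a 1.8-fold higher number from compound 3 to compound 4 (0.26 log units; within the scatter), so the large step seen on the core of compound 1 does not carry over to this core in size. The same change therefore cannot be transferred from one core to the other as a fixed shift in this series: the same change on two cores in this assay, a 20-fold higher number (1.30 log units; beyond the scatter) from compound 2 to compound 1 and a 1.8-fold higher number (0.26 log units; within the scatter) from compound 3 to compound 4, 11-fold (1.03 log units) apart, beyond the scatter of two such steps. This shows only that the size of the step depends on its surroundings in these two pairs; the pairs differ in more than one place outside the change, so the data do not say which difference accounts for the gap, and two pairs set no general rule.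

Open, as far as these compounds go, is whether the large step returns on the core of compound 3 when its side chain ends in a plain methyl, as in compound 2. Also open, from the compounds shown here alone, is whether a chlorine or a nitrile at the place of the trifluoromethyl tracks trifluoromethyl or hydrogen on either core.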